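From a furan to a phenyl on the cyanoacrylamide chain

The compounds below may be only part of what the source reports. "The series", "measured", "known", "first", "only" and "open" are said of these compounds alone.

Of the compounds shown here, three have so far been measured in a functional assay on DU-145 cells (Homo sapiens) for inhibition, read by MTT assay, with a stated time of 72 h; on this read-out lower numbers stand for stronger inhibition of growth and higher numbers for weaker inhibition of growth. Compound 1 `N#C/C(=C\c1ccc[nH]1)C(=O)NCc1ccc(Cl)c(Cl)c1` carries a 1H-pyrrol-2-yl group on a double-bonded chain carbon. In this assay compound 1 gives > 50000 nM, which is a limit of the assay rather than a number. Compound 2 `N#C/C(=C\c1ccco1)C(=O)NCc1ccc(Cl)c(Cl)c1` carries furan-2-yl in the same place, and in this assay compound 2 gives 24000 nM. That change amounts to an at least 2.0-fold lower number from compound 1 to compound 2 (0.31 log units; beyond the scatter). Compound 3 `COc1ccc(CNC(=O)/C(C#N)=C/c2cc(Br)co2)cc1` has a brominated furan and a different amide side, and in this assay compound 3 gives 61000 nM, a higher number than compound 2 by a gap beyond the scatter. Compound 2 therefore stands lowest of the two numbers seen, while one value sits at the limit of > 50000 nM in this assay, at which 1 of the 3 values shown sits.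

Compound 4 `N#C/C(=C\c1ccccc1)C(=O)NCc1ccc(Cl)c(Cl)c1` has not been measured. It differs from compound 2 by phenyl in place of furan-2-yl on a double-bonded chain carbon bound to a double-bonded chain carbon. Going by the values given here, the one measured step at this place, an at least 2.0-fold lower number from compound 1 to compound 2 (0.31 log units; beyond the scatter), swapped one five-membered ring for another; no measured step swaps a five-membered ring for a six-membered ring of carbon only. The expected step is therefore small and of uncertain direction, a 1.3-fold higher number from compound 2 to compound 4 (0.10 log units; within the scatter). Compound 4 is estimated at 30000 nM, in a range from 8000 nM to 100000 nM.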

Compound 4, concentration for 50% growth inhibition: 71000 nM
Estimate against measurement, compound 4: 2.4-fold (0.37 log units) below; measured number inside the range.
By their numbers in this assay, from the lowest: compound 2; then compounds 3 and 4 (each within the scatter of the next).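

Replacing the five-membered furan-2-yl with the six-membered phenyl on this double-bonded chain carbon matters in this assay: the swap gives a 3.0-fold higher number from compound 2 to compound 4 (0.47 log units; beyond the scatter). This position therefore responds to a change from a five-membered ring with a hetero atom to a six-membered ring of carbon only, and not just to the exchange of one five-membered ring for another. Among compound 1, compound 2 and compound 4, which differ only at this place, furan-2-yl gives the lowest number, but the step between compound 1 and compound 4 cannot be read, since compound 1 carries a limit of the assay and not a number: the limit of > 50000 nM in this assay, at which 1 of the 4 values shown sits.

The new step changes two things at once, the ring size and the presence of the ring oxygen, and these numbers do not separate the two. A pyridin-2-yl group, a six-membered ring holding a nitrogen, or a thiophen-2-yl group, a five-membered ring holding a sulfur, on the same carbon would pull them apart.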